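From methoxycarbonyl to ethoxycarbonyl at the assay limit

The compounds below may be only part of what the source reports. "The series", "measured", "known", "first", "only" and "open" are said of these compounds alone.

Compound 1 (`C#CCOC(=O)C[C@@H]1C(C(=O)OC)=CO[C@@H](O[C@@H]2O[C@H](COC(C)=O)[C@@H](OC(C)=O)[C@H](OC(C)=O)[C@H]2OC(C)=O)/C1=C/C`) and compound 2 (`C/C=C1/[C@H](O[C@@H]2O[C@H](COC(C)=O)[C@@H](OC(C)=O)[C@H](OC(C)=O)[C@H]2OC(C)=O)OC=C(C(=O)OC)[C@H]1CC(=O)OC`) share one core. In a functional assay on SK-BR-3 cells (Homo sapiens) for antiproliferative activity, read by MTT assay, with a stated time of 72 h (on this read-out lower numbers stand for stronger inhibition and higher numbers for weaker inhibition), compound 1 gives > 15000 nM as a limit and not a number. In this assay compound 2 gives > 15000 nM as a limit too. Both values fall under the limit of > 15000 nM in this assay, at which 2 of the 2 values shown sit, and neither is a number.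

Compound 3 (`C/C=C1/[C@H](O[C@@H]2O[C@H](COC(C)=O)[C@@H](OC(C)=O)[C@H](OC(C)=O)[C@H]2OC(C)=O)OC=C(C(=O)OC)[C@H]1CC(=O)OCC`) follows from compound 2 by methyl in place of hydrogen on a saturated chain carbon bound to an oxygen next to a carbonyl group, which reads as methoxycarbonyl to ethoxycarbonyl. Among the measured compounds shown here, the only measured step at this place is a step that the two limits leave unreadable from compound 1 to compound 2 and it offers no size to carry over. No change beyond the scatter is expected, and the estimated outcome is a step that the limit leaves unreadable from compound 2 to compound 3 with no direction readable. Compound 3 is expected at 20000 nM within a range of 8000 nM to 50000 nM and will most likely be reported as a limit again.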

Compound 3, half-maximal inhibitory concentration: > 15000 nM
Compound 3: only a limit was reported (the forecaster's own chance of this, stated with the estimate: 85%); the middle value lies beyond the limit too.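

In this assay, no step among compound 1, compound 2 and compound 3 can be read, and all three values are limits and not numbers: the limit of > 15000 nM in this assay, at which 3 of the 3 values shown sit.

The compounds shown leave open how these three rank against one another and whether any group at this place gives a measurable value.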